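A Nitrophenyl Swap on a Scaffold Without Measurable Cytotoxicity

This account rests on a few compounds, and the source may have more. Where it says the series, first, only, none or still open, it means among the compounds named here.

Compound 1 `CCOC(=O)c1c(-c2cc(F)cc(OC)c2)[nH]c2cc(OC)ccc2c1=O` was examined in an ADME assay on HepG2 cells (Homo sapiens) for cytotoxicity, read by luminescence, with a stated time of 72 h; a higher number here means that more compound is needed for the effect, a lower number that less compound is needed. In this assay compound 1 gives > 21500 nM, which is a limit of the assay and not a number. Compound 2 `CCOC(=O)c1c(-c2cccc(C(F)(F)F)c2)[nH]c2cc(OC)ccc2c1=O`, carrying a trifluoromethyl group on the pendant ring, behaves the same way: in this assay compound 2 gives > 21500 nM, again a limit rather than a number. Compound 1 therefore stands where both values shown stand, at the limit of > 21500 nM in this assay, at which 2 of the 2 values shown sit, and nothing separates it from compound 2 on these numbers.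

Compound 3 `CCOC(=O)c1c(-c2cccc([N+](=O)[O-])c2)[nH]c2cc(OC)ccc2c1=O` has not yet been measured. It differs from compound 1 in one place: 3-nitrophenyl in place of 3-fluoro-5-methoxyphenyl on an aromatic carbon. Going by the values given here, no step between two measured compounds is available here, so the size of this change can only be expected, not read off. Both measured compounds sit at the limit of > 21500 nM in this assay, at which 2 of the 2 values shown sit, and on that basis the expected step is a step that the limit leaves unreadable from compound 1 to compound 3, amounting to nothing beyond the scatter. For compound 3 the estimate in this assay is 30000 nM, with a range from 15000 nM to 100000 nM, most likely reported only as a limit.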

Compound 3, half-maximal effective concentration: > 21500 nM
Compound 3 gave a limit, no number (the forecaster's own chance of this, stated with the estimate: 80%); the middle value does not contradict the limit.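

In this assay compound 3 also gives only a limit, so neither the step from compound 1 to compound 3 nor the step from compound 2 to compound 3 can be read: the limit of > 21500 nM in this assay, at which 3 of the 3 values shown sit. The compounds shown leave open whether any group at this aromatic carbon would give a number in this assay rather than a limit.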